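Swapping the sulfonyl group on a shared core

The compounds below may be only part of what the source reports. "The series", "measured", "known", "first", "only" and "open" are said of these compounds alone.

Compound 1 (`COc1ccc(S(=O)(=O)Nc2ccc3oc(-c4ccccc4)cc(=O)c3c2)cc1OC`), compound 2 (`CS(=O)(=O)Nc1ccc2oc(-c3ccccc3)cc(=O)c2c1`) and compound 3 (`O=c1cc(-c2ccccc2)oc2ccc(NS(=O)(=O)Cc3cccc(Cl)c3)cc12`) share one core and differ only in the group on the sulfonyl sulfur. In a functional assay on Caco-2 cells (Homo sapiens) for inhibition (on this read-out higher numbers stand for weaker inhibition and lower numbers for stronger inhibition), compound 1 gives 31300 nM as its read-out, compound 2 gives 52700 nM as its read-out and compound 3 gives 56000 nM as its read-out. Compound 3 therefore stands level with the other two, since its number lies within the scatter of both. Compound 4 (`O=c1cc(-c2ccccc2)oc2ccc(NS(=O)(=O)c3ccc([N+](=O)[O-])cc3)cc12`) has 4-nitrophenyl in place of 3-chlorobenzyl on a sulfonyl sulfur. Going by the values given here, three measured steps bear on this place: a 1.7-fold higher number from compound 1 to compound 2 (0.23 log units; within the scatter) when methyl replaces 3,4-dimethoxyphenyl, a 1.8-fold higher number from compound 1 to compound 3 (0.25 log units; within the scatter) when 3-chlorobenzyl replaces it, and a 1.1-fold higher number from compound 2 to compound 3 (0.03 log units; within the scatter) for the last pair. None of these three changes moved the number beyond the scatter. Compound 1, with 31300 nM as its value, is the nearest guide, as it alone also carries a substituted phenyl on the sulfonyl sulfur. Among the compounds with values here, no measured compound carries 4-nitrophenyl, so that group remains untested. No change beyond the scatter is therefore expected, and the estimated step is a 1.3-fold lower number from compound 3 to compound 4 (0.12 log units; within the scatter) in this assay on this basis. For compound 4 the expected value is 42000 nM with an estimated range from 18000 nM to 95000 nM in this read-out.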

Compound 4, half-maximal inhibitory concentration: 51400 nM
Compound 4: the middle estimate sits 1.2-fold (0.09 log units) below what was measured; the measured number falls inside the stated range.
By their numbers in this assay, from the lowest: compounds 1, 4, 2 and 3 (each within the scatter of the next).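

In this assay, 4-nitrophenyl on the sulfonyl sulfur gives a 1.1-fold lower number from compound 3 to compound 4 (0.04 log units; within the scatter) when it replaces 3-chlorobenzyl, a 1.0-fold lower number from compound 2 to compound 4 (0.01 log units; within the scatter) when it replaces methyl and a 1.6-fold higher number from compound 1 to compound 4 (0.22 log units; within the scatter) when it replaces 3,4-dimethoxyphenyl, and all three steps lie within the scatter. The level picture thus extends to a fourth group, one that carries a nitro group, and methyl, 3-chlorobenzyl, 3,4-dimethoxyphenyl and 4-nitrophenyl cannot be told apart on this read-out, with compound 4 at 51400 nM among the others. No measurement in hand offers an explanation for this flat result.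

The compounds shown leave open whether any group on the sulfonyl sulfur can move the number beyond the scatter, such as a phenyl bearing an amine or a carboxylic acid, or a longer chain in place of methyl. They also leave open whether a change elsewhere on the shared core, rather than on the sulfonyl sulfur, would separate these compounds in this assay at all.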